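This account rests on a few compounds, and the source may have more. Where it says the series, first, only, none or still open, it means among the compounds named here.

The measured compounds in an ADME assay on MRC5 cells (Homo sapiens) for inhibition, with a stated time of 72 h; on this read-out higher numbers stand for an effect only at larger amounts of compound and lower numbers for an effect already at smaller amounts:
Compound 1, `CO[C@H]1CC[C@H](NC(=O)c2n[nH]cc2NC(=O)c2cnc3ccccn23)CC1`, gives 5900 nM.
Compound 2, `COc1cccc(OC)c1C(=O)Nc1c[nH]nc1C(=O)N[C@H]1CC[C@H](O)CC1`, gives 34000 nM.
Compound 3, `COc1cccc(OC)c1C(=O)Nc1c[nH]nc1C(=O)NC1CCN(Cc2ccccc2)C1`, gives 38000 nM.

Among these three numbers compound 2 sits second from the top. Compound 3 lies very close to it, and that gap falls within the usual scatter of repeated measurements, so no order between compound 2 and compound 3 can be read from the numbers. Compound 1 gives a lower number, and that gap lies beyond the scatter.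

Compound 4, `CCCCCNC(=O)c1n[nH]cc1NC(=O)c1c(OC)cccc1OC`, has not yet been measured in this assay. It arises from compound 2 through a single change: pentyl in place of 4-hydroxycyclohexyl on an amide-type nitrogen. Compound 2 and compound 3 carry quite different groups on the amide-type nitrogen yet give numbers within the scatter of each other, which hints that a change at this place moves the number little. Going by the values given here, no pair with a pentyl group exists here, so the expectation rests on thin ground. The expected step is a 1.2-fold lower number from compound 2 to compound 4 (0.08 log units; within the scatter), within the scatter. Compound 4 is estimated at 28000 nM, with a likely range from 9000 nM to 85000 nM.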

Compound 4, half-maximal effective concentration: > 50000 nM
Compound 4 gave a limit, no number (the forecaster's own chance of this, stated with the estimate: 25%); at least 1.7-fold (0.25 log units) between middle value and limit.
By their numbers in this assay, from the lowest: compound 1; then compounds 2 and 3 (each within the scatter of the next). At a limit, above all of these: compound 4.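

In this assay compound 4 gives > 50000 nM, which is a limit of the assay and not a number. Exchanging 4-hydroxycyclohexyl for pentyl on the amide-type nitrogen, which removes the ring and the hydroxyl group, gives an at least 1.4-fold higher number from compound 2 to compound 4 (0.16 log units; that floor lies within the scatter), so this open chain brings no lower number at this position, though a real rise is not shown either. How large the step truly is cannot be read, as the reading ends at the limit: the limit of > 50000 nM in this assay, at which 1 of the 4 values shown sits.

As far as these compounds go, whether a shorter chain, a chain ending in an amine or one ending in a carboxylic acid on this nitrogen would shift the number remains open. Compound 1 differs from compound 2 in more than one place, so the compounds shown do not tell which of those differences goes with its lower number.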